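Swapping a methoxy for methylamino on compound 3

The source may report more compounds than this note shows. Statements on the series, on what has been measured and on what is new or still open speak of the compounds shown alone.

Compound 1 `Cn1ncc2c(NS(=O)(=O)c3cccc(Cl)c3Cl)ccnc21`: >= 310000 nM (a limit)
Compound 2 `COCCn1nc(OC)c2c(NS(=O)(=O)c3cccc(Cl)c3Cl)ncnc21`: >= 442000 nM (a limit)
Compound 3 `COc1nc(NS(=O)(=O)c2cccc(Cl)c2Cl)c2c(OC)nn(C)c2n1`: 148000 nM

All three compounds were tested in a physicochemical assay for solubility, read by chemiluminescence, measured as kinetic solubility; on this read-out higher numbers stand for higher solubility and lower numbers for lower solubility. Compound 1 gives >= 310000 nM, which is a limit of the assay and not a number. Compound 2 gives >= 442000 nM, which is also a limit. Among the compounds with values here, compound 3, at 148000 nM, therefore holds the only true number in the set, and it makes a firm starting point.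

Compound 4 `CNc1nc(NS(=O)(=O)c2cccc(Cl)c2Cl)c2c(OC)nn(C)c2n1` keeps the core of compound 3, with one change: methylamino in place of methoxy on an aromatic carbon, between two ring nitrogen atoms (methylamino in place of methoxy on an aromatic carbon). Within the data shown here, no pair of measured compounds differs in just one place, so the data do not size this swap directly. In this assay, the expectation is therefore no step beyond the usual scatter, with only a slight lean towards lower numbers. The estimated step of a 1.2-fold lower number from compound 3 to compound 4 (0.09 log units; within the scatter) is correspondingly small. For compound 4 the estimated value is 120000 nM, with an expected range of 40000 nM to 350000 nM.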

Compound 4, solubility: 376000 nM
Estimate against measurement, compound 4: 3.1-fold (0.50 log units) below; the measured number lies above the stated range.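

In this assay, within the data shown here, methylamino in place of methoxy on an aromatic carbon, between two ring nitrogen atoms, gives a 2.5-fold higher number from compound 3 to compound 4 (0.40 log units; beyond the scatter) and is the first single change that can be read in this set. So this position is not silent: a swap that leaves the heavy-atom count unchanged still moves the number beyond the scatter, and methylamino brings a hydrogen-bond donor that methoxy lacks. Nothing measured here accounts for the step, however, so it stands as an observation without a cause.

From the compounds shown here alone, it remains open whether the step follows that donor hydrogen or the nitrogen itself, which a dimethylamino group at the same position would help to separate. A longer chain such as ethylamino or an amine-bearing side chain could show how much further this position responds.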